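This account rests on a few compounds, and the source may have more. Where it says the series, first, only, none or still open, it means among the compounds named here.

Compound 1 `NC(=O)CCn1ccc2c(Nc3ccc(OC(F)(F)F)cc3)ncnc21` was tested in an ADME assay on BaF3 cells (Mus musculus) for cytotoxicity (on this read-out lower numbers stand for an effect already at smaller amounts and higher numbers for an effect only at larger amounts of compound), where compound 1 reaches only the limit of the assay, > 10000 nM. Compound 2 `COC(=O)c1cc2c(Nc3ccc(OC(F)(F)F)cc3)ncnc2s1` likewise reaches only the assay limit, > 10000 nM. Going by the values given here, both values thus sit at the limit of > 10000 nM in this assay, at which 2 of the 2 values shown sit, so no measured step connects them. Compound 3 `Cn1ccc2c(Nc3ccc(OC(F)(F)F)cc3)ncnc21` differs from compound 1 by hydrogen in place of carbamoylmethyl on a saturated chain carbon bound to an aromatic nitrogen. Among the compounds with values here, no step of this kind has been measured. The expected step is a step that the limit leaves unreadable from compound 1 to compound 3, none beyond the usual scatter. Compound 3 is therefore estimated at 15000 nM, within a range from 5000 nM to 50000 nM, most probably reported again only as a limit.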

Compound 3, half-maximal effective concentration: > 10000 nM
Compound 3: no number, only a limit (the forecaster's own chance of this, stated with the estimate: 80%); the middle value lies beyond the limit too.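

No step can be read between compound 1 and compound 3, because both values are only limits: the limit of > 10000 nM in this assay, at which 3 of the 3 values shown sit.

The compounds shown leave open at what concentration any of them would show an effect in this assay, and whether replacing 2-carbamoylethyl with methyl changes that concentration.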